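Compound 4: Isopropoxymethyl Replacing Isopropyl on the Amine Chain

The compounds below may be only part of what the source reports. "The series", "measured", "known", "first", "only" and "open" are said of these compounds alone.

In an ADME assay on cells (Homo sapiens) for cytotoxicity, read by polymerase chain reaction, with a stated time of 3 days (on this read-out higher numbers stand for lower toxicity in this test and lower numbers for higher toxicity in this test), compound 3 (`Cc1nc(NCC(C)C)nc(N[C@@H]2C[C@H](CO)[C@@H](O)[C@H]2O)c1-c1nc2ccccc2s1`) gives 10000 nM and compound 1 (`CCNc1nc(C)c(-c2nc3ccccc3s2)c(N[C@@H]2C[C@H](CO)[C@@H](O)[C@H]2O)n1`) gives 12000 nM, two values within the scatter of each other. Compound 2 (`CCCNc1nc(C)c(-c2nc3ccccc3s2)c(N[C@@H]2C[C@H](CO)[C@@H](O)[C@H]2O)n1`) reads > 25000 nM, which is a limit of the assay and not a number.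

The next change leads to compound 4 (`Cc1nc(NCCOC(C)C)nc(N[C@@H]2C[C@H](CO)[C@@H](O)[C@H]2O)c1-c1nc2ccccc2s1`): isopropoxymethyl in place of isopropyl on a saturated chain carbon bound to a nitrogen on an aromatic ring. Within the data shown here, no measured step brings an oxygen into this chain, so the evidence is indirect. Three chain steps bear on it. The closest is a 1.2-fold lower number from compound 1 to compound 3 (0.08 log units; within the scatter), while an at least 2.0-fold higher number from compound 1 to compound 2 (0.31 log units; beyond the scatter) and an at least 2.5-fold lower number from compound 2 to compound 3 (0.39 log units; beyond the scatter) show that small chain changes can exceed the scatter, and both rest on the limit of compound 2.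

A step beyond the scatter is therefore not expected, though a modest rise remains possible. The expected step is a 1.4-fold higher number from compound 3 to compound 4 (0.15 log units; within the scatter). Compound 4 is estimated at 14000 nM, with an expected range of 7000 nM to 28000 nM.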

Compound 4, half-maximal cytotoxic concentration: 8000 nM
Compound 4: the middle estimate sits 1.8-fold (0.24 log units) above what was measured; low and high end bracket the measured number.
By their numbers in this assay, from the lowest: compounds 4, 3 and 1 (each within the scatter of the next). At a limit, above all of these: compound 2.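

The 2-isopropoxyethyl chain shows that this position takes an ether oxygen and a larger group without a step beyond the scatter in this assay: a 1.3-fold lower number from compound 3 to compound 4 (0.10 log units; within the scatter), and a 1.5-fold lower number from compound 1 to compound 4 (0.18 log units; within the scatter). Compounds 1, 3 and 4 thus form one group despite their different chains, and compound 2 is the exception. The only step here beyond the scatter, an at least 3.1-fold lower number from compound 2 to compound 4 (0.49 log units; beyond the scatter), gives a minimum and not a size, and it rests on a single limit: the limit of > 25000 nM in this assay, at which 1 of the 4 values shown sits.

Open, from the compounds shown here alone, is whether the oxygen or the added chain length matters more, as a 4-methylpentyl chain would separate the two. Also open, going by these compounds, is how this read-out responds to a chain ending in an amine or a carboxylic acid.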